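The source may report more compounds than this note shows. Statements on the series, on what has been measured and on what is new or still open speak of the compounds shown alone.

Measured so far, in an assay on SHEP1 cells for displacement of a labelled ligand from Neuronal acetylcholine receptor; alpha4/beta2 (Homo sapiens), read by scintillation counting, with a stated time of 2 h; a higher number here means a weaker inhibitor, a lower number a stronger inhibitor:
- compound 1, `C[C@H]1C[C@H]1C(=O)N1CC2CNCC2C1`, gives 18 nM
- compound 2, `C[C@H]1C[C@@H]1C(=O)N1CC2CNCC2C1`, gives 43 nM
- compound 3, `CCC(=O)N1CC2CNCC2C1`, gives 12 nM

Compound 3 has the lowest of the three numbers. Its nearest neighbour is compound 1, reached by a 1.5-fold lower number from compound 1 to compound 3 (0.18 log units; within the scatter), so these two cannot be told apart; compound 2 lies further off, a 3.6-fold lower number from compound 2 to compound 3 (0.55 log units; beyond the scatter). The two stereoisomers themselves differ by a 2.4-fold higher number from compound 1 to compound 2 (0.38 log units; beyond the scatter).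

Compound 4, `COC(=O)N1CC2CNCC2C1`, has not yet been measured. It differs from compound 3 by methoxy in place of ethyl on a carbonyl carbon. Going by the values given here, no measured step swaps the ethyl for an oxygen-bearing group; the only steps that touch the carbonyl substituent are the swaps of the 2-methylcyclopropyl for ethyl, a 1.5-fold lower number from compound 1 to compound 3 (0.18 log units; within the scatter) and a 3.6-fold lower number from compound 2 to compound 3 (0.55 log units; beyond the scatter), both modest at most. On that basis the new change is expected to move this assay by no more than a modest amount, with a weakening slightly more likely than a strengthening, an expected step of a 2.1-fold higher number from compound 3 to compound 4 (0.32 log units; beyond the scatter). Compound 4 is therefore estimated at 25 nM, within 8 nM to 80 nM.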

Compound 4, inhibition constant: 23 nM
Beside the measured number, compound 4's estimate is 1.1-fold (0.04 log units) above it; measured number inside the range.
By their numbers in this assay, from the lowest: compounds 3, 1, 4 and 2 (each within the scatter of the next, the first and the last beyond it).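

Swapping ethyl for methoxy on the carbonyl carbon, which turns propanoyl into methoxycarbonyl and adds a hydrogen-bond acceptor, gives a step in this assay that stays within the scatter (a 1.9-fold higher number from compound 3 to compound 4 (0.28 log units; within the scatter)). Methoxy also cannot be told apart from either 2-methylcyclopropyl group (a 1.3-fold higher number from compound 1 to compound 4 (0.11 log units; within the scatter); a 1.9-fold lower number from compound 2 to compound 4 (0.27 log units; within the scatter)), so this place can carry an oxygen-bearing group without a clear change in the number, even though compound 2 and compound 3 do differ beyond the scatter. Nothing available explains why this swap behaves as it does.

Still open, going by these compounds, is whether a longer chain such as butoxy or a phenyl ring on the carbonyl carbon would leave the number in this range. Also open, on these data alone, is what an amine at the same place, such as dimethylamino, would do.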